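Series notes: aryl change on the enone carbonyl

The compounds below may be only part of what the source reports. "The series", "measured", "known", "first", "only" and "open" are said of these compounds alone.

Of the compounds shown here, two of the shared core carry numbers so far. Compound 1 `COc1ccc(-c2cc(/C=C/C(=O)c3ccc(N)cc3)[nH]n2)cc1` gives in a functional assay on PC-3 cells (Homo sapiens) for inhibition, read by sulforhodamine B assay, with a stated time of 48 h (on this read-out higher numbers stand for weaker inhibition of growth and lower numbers for stronger inhibition of growth), a value of 10100 nM. Compound 2 `COc1cc(-c2cc(/C=C/C(=O)c3ccc(N)cc3)[nH]n2)cc(OC)c1OC` gives in this assay a value of 10400 nM, the highest of the two numbers, though its gap to compound 1 sits within the scatter, so the two tell no order between them.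

The next step goes from compound 2 to compound 3 `COc1cc(-c2cc(/C=C/C(=O)c3ccc(Cl)c(Cl)c3)[nH]n2)cc(OC)c1OC`, which has not yet been measured in this assay. The change is 3,4-dichlorophenyl in place of 4-aminophenyl on a carbonyl carbon. No step between measured compounds in this series touches that part of the molecule, so there is no shown step to lean on; the expectation rests on the two values alone and on the size of the change, which swaps the only hydrogen-bond donor and acceptor of that aryl group for two chlorine atoms.

For compound 3 the expected step of a 2.1-fold lower number from compound 2 to compound 3 (0.32 log units; beyond the scatter) is a modest shift towards stronger inhibition of growth, of a size not far beyond the scatter, with the direction uncertain. The estimate for compound 3 in this assay is 5000 nM, with a range from 1000 nM to 25000 nM.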

Compound 3, concentration for total growth inhibition: > 100000 nM
Compound 3 ended at the assay's limit; the forecaster's own chance of this, stated with the estimate: 10%; at least 20-fold (1.30 log units) between middle value and limit.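

The place on the carbonyl carbon is not indifferent to its aryl group: 3,4-dichlorophenyl in place of 4-aminophenyl gives an at least 9.6-fold higher number from compound 2 to compound 3 (0.98 log units; beyond the scatter), towards weaker inhibition of growth, and this is the only step shown so far that lies beyond the scatter. Compound 3 reads > 100000 nM in this assay, which is a limit of the assay and not a number, so the step has a floor but no known size: the limit of > 100000 nM in this assay, at which 1 of the 3 values shown sits. Compound 1 and compound 2 both carry 4-aminophenyl at this place and could say nothing about it, whereas the pair of compound 2 and compound 3 shows that the read-out depends on the aryl group here.

This single swap removes the amine and brings in two chlorine atoms together, so the compounds shown do not tell which of the two parts carries the step. A plain phenyl, a phenyl with one chlorine, or a phenyl with a hydroxyl in place of the amine would separate these parts, and the same swap on the core of compound 1 would show whether the step holds with the other aryl group.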